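The source may report more compounds than this note shows. Statements on the series, on what has been measured and on what is new or still open speak of the compounds shown alone.

Compound 2 `COc1ccc(-n2cc(COc3ccc(C[C@H]4C(=O)OC[C@@H]4Cc4ccc(OC)c(OC)c4)cc3OC)nn2)cc1` is the starting point here. In an ADME assay on HeLa cells (Homo sapiens) for cytotoxicity, read by MTT assay (on this read-out lower numbers stand for stronger inhibition and higher numbers for weaker inhibition), compound 2 gives >= 600000 nM, which is a limit of the assay and not a measured number. The same limit appears for compound 1 `COC(=O)[C@@H](NC(=O)CCC(=O)Oc1ccc(C[C@H]2C(=O)OC[C@@H]2Cc2ccc(OC)c(OC)c2)cc1OC)c1c[nH]c2ccccc12`: in this assay compound 1 gives >= 600000 nM, again a limit rather than a number. Going by the values given here, compound 3 `COC(=O)CNC(=O)CCC(=O)Oc1ccc(C[C@H]2C(=O)OC[C@@H]2Cc2ccc(OC)c(OC)c2)cc1OC` is the only member of this set with a measured number, and in this assay compound 3 gives 179000 nM. Among the compounds with values here, the one step with a size is an at least 3.3-fold lower number from compound 1 to compound 3 (0.52 log units; beyond the scatter), and it is the only step available, while compound 2 stands together with compound 1 at the limit, as the limit of >= 600000 nM in this assay, at which 2 of the 3 values shown sit, shows.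

Compound 4 `COc1ccc(C[C@H]2COC(=O)[C@@H]2Cc2ccc(OCc3cn(-c4ccc(Cl)cc4)nn3)c(OC)c2)cc1OC` differs from compound 2 by chloro in place of methoxy on an aromatic carbon. Within the data shown here, no measured step in this set bears on such a change, and the step from compound 1 to compound 3 concerns an unrelated part of the molecule. Since compound 2 sits at the limit, the step expected from compound 2 to compound 4 in this assay is a number no higher from compound 2 to compound 4 (the limit leaves the size open), that is, none beyond the scatter. Compound 4 is therefore expected to give about 600000 nM in this assay, within a range from 250000 nM to 1500000 nM.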

Compound 4, half-maximal inhibitory concentration: 279000 nM
The estimate for compound 4 lay 2.2-fold (0.33 log units) above the measured number; the range from low to high includes it.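

In this assay, replacing methoxy with chloro on an aromatic carbon, para to a large group, gives an at least 2.1-fold lower number from compound 2 to compound 4 (0.33 log units; beyond the scatter), so the change from 4-methoxyphenyl to 4-chlorophenyl is enough to bring the read-out off the limit. Going by these compounds alone, the earlier compounds offered only one step, at a saturated chain carbon in another part of the molecule, and nothing about this aryl position; this is the first sign that the number responds to what sits on this ring, and compound 4 now gives this series a measured value at this position. The true size of the step stays open, however, because compound 2 has no measured number, only a limit: the limit of >= 600000 nM in this assay, at which 2 of the 4 values shown sit.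

The compounds shown leave open whether the lower number belongs to chloro in particular or would also follow from plain hydrogen, fluoro, bromo, methyl, an amine or a carboxylic acid at the same place. They also leave open whether the same exchange would have a similar effect on a member of the series with a different linking chain, such as compound 3 or compound 1.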